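A Methoxypyridyl Replacement for Phenyl in Compound 3

This account rests on a few compounds, and the source may have more. Where it says the series, first, only, none or still open, it means among the compounds named here.

Of the compounds shown here, three sharing one core have been measured in an in vitro assay on HEK385-7 cells for displacement of a labelled ligand from prostaglandin D2 receptor 2 (Homo sapiens); a higher number here means a weaker inhibitor, a lower number a stronger inhibitor. Compound 1 `O=C(O)Cc1sc(NCc2ccccc2)nc1-c1ccc(Cl)cc1` gives 440 nM, and compound 2 `O=C(O)Cc1sc(C(c2ccccc2)c2ccccn2)nc1-c1ccc(Cl)cc1` gives 810 nM. Compound 3 `O=C(O)Cc1sc(C(c2ccc(F)cc2)c2ccc(F)cc2)nc1-c1ccccc1` gives 16 nM, the lowest of the three numbers; its gaps to compound 1 and to compound 2 both lie beyond the scatter, so compound 3 stands as the strongest inhibitor of the set. For the measured compounds named here, no pair among the three differs in only one place, so no single step between measured compounds can be read from these data.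

Compound 4 `COc1cc(-c2nc(C(c3ccc(F)cc3)c3ccc(F)cc3)sc2CC(=O)O)ccn1` has not yet been measured. It differs from compound 3 in one place: 2-methoxypyridin-4-yl in place of phenyl on an aromatic carbon. The rest of the structure, including the carboxymethyl group and the large group on the far side of the core, is unchanged.

Going by the values given here, with no comparable step among the measured compounds, the expectation for compound 4 rests on compound 3 alone, whose value of 16 nM is the starting point. The step of a 1.6-fold higher number from compound 3 to compound 4 (0.19 log units; within the scatter) is expected to be small, most likely within the scatter, with the direction uncertain. Compound 4 is therefore estimated at 25 nM in this assay, with a range from 6 nM to 100 nM.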

Compound 4, half-maximal inhibitory concentration: 29 nM
The estimate for compound 4 lay 1.2-fold (0.06 log units) below the measured number; measured number inside the range.
By their numbers in this assay, from the lowest: compounds 3 and 4 (each within the scatter of the next); then compounds 1 and 2 (each within the scatter of the next).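

In this assay, for the compounds shown here, 2-methoxypyridin-4-yl in place of phenyl gives a 1.8-fold higher number from compound 3 to compound 4 (0.26 log units; within the scatter) and so supplies the first step in the set that changes one place only. This step shows that the aromatic carbon next to the ring nitrogen and next to the ring atom bearing the carboxymethyl group accepts a swap from a carbon-only ring to one with a hetero atom, with the heavy atoms going from 6 to 8 and the hydrogen-bond acceptors from 0 to 2, without a difference beyond the scatter when the large group carries two 4-fluorophenyl rings. No measurement is available that would explain this result.

The swap brings in the ring nitrogen and the methoxy group together, so this pair cannot show what each does alone; a plain pyridinyl ring or a methoxyphenyl group would be needed to tell them apart. It also leaves open how this position responds to groups of another kind, such as an amine, a carboxylic acid or a longer alkoxy chain on the ring.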